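The source may hold more compounds than are shown below. What is called first, only, known or untested is meant among the compounds shown, and "the series" means these compounds.

Values in a functional assay on MDA-MB-436 cells (Homo sapiens) for antiproliferative activity, read by MTT assay, with a stated time of 48 h; on this read-out higher numbers stand for weaker inhibition and lower numbers for stronger inhibition:
- compound 1 `C=CS(=O)(=O)N1CCN(c2ncnc3sc(-c4ccnc(Cl)c4)cc23)CC1`: 30100 nM
- compound 2 `C=CS(=O)(=O)N1CCN(c2ncnc3sc(-c4ccc(OC)nc4)cc23)CC1`: 11900 nM
- compound 3 `C=CS(=O)(=O)N1CCN(c2ncnc3sc(-c4ccc(F)nc4)cc23)CC1`: 17500 nM

Compound 3 cannot be separated from either of the other two on these numbers: a 1.7-fold lower number from compound 1 to compound 3 (0.24 log units; within the scatter), and a 1.5-fold higher number from compound 2 to compound 3 (0.17 log units; within the scatter). Only the outer pair differs beyond the scatter, and modestly: a 2.5-fold lower number from compound 1 to compound 2 (0.40 log units; beyond the scatter).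

Compound 4 `C=CS(=O)(=O)N1CCN(c2ncnc3sc(-c4cc(Br)cnc4F)cc23)CC1` is the next case, with the change (5-bromo-2-fluoropyridin-3-yl in place of 6-fluoropyridin-3-yl on an aromatic carbon). In words, this is 5-bromo-2-fluoropyridin-3-yl in place of 6-fluoropyridin-3-yl on an aromatic carbon, next to the ring sulfur. Within the data shown here, no measured compound carries a bromine, so no step speaks to that atom directly. The nearest evidence is the other exchanges of the pyridinyl group at this carbon, and the largest of them is the modest 2.5-fold lower number from compound 1 to compound 2 (0.40 log units; beyond the scatter). In this assay a small step of no firm direction is therefore expected, most likely none beyond the scatter. The expected change is a 1.2-fold lower number from compound 3 to compound 4 (0.07 log units; within the scatter). The estimate for compound 4 is 15000 nM, with an expected range of 7000 nM to 32000 nM.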

Compound 4, half-maximal inhibitory concentration: 28400 nM
Estimate against measurement, compound 4: 1.9-fold (0.28 log units) below; measured number inside the range.
By their numbers in this assay, from the lowest: compounds 2, 3, 4 and 1 (each within the scatter of the next, the first and the last beyond it).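

In this assay, 5-bromo-2-fluoropyridin-3-yl in place of 6-fluoropyridin-3-yl, on the aromatic carbon next to the ring sulfur, cannot be separated from the parent group: a 1.6-fold higher number from compound 3 to compound 4 (0.21 log units; within the scatter). The bromine-bearing group is also not separable from 2-chloropyridin-4-yl, a 1.1-fold lower number from compound 1 to compound 4 (0.03 log units; within the scatter), while against 6-methoxypyridin-3-yl it gives a modest gap, a 2.4-fold higher number from compound 2 to compound 4 (0.38 log units; beyond the scatter), of about the same size as a 2.5-fold lower number from compound 1 to compound 2 (0.40 log units; beyond the scatter). No evidence here accounts for these values.

The contribution of the bromine alone stays unresolved, as the two group names also differ in where the fluoro stands. Also open, from the compounds shown here alone, is whether a pyridinyl group carrying an amine or a carboxylic acid at this carbon would give a number outside the narrow span seen so far.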